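Sulfonyl aryl swap in the trifluoromethyl hydroxy-amide series

The compounds below may be only part of what the source reports. "The series", "measured", "known", "first", "only" and "open" are said of these compounds alone.

Of the compounds shown here, three of one shared core have been measured in a functional assay (Cavia porcellus) with sulfonylurea receptors; K-ATP channels (Homo sapiens) as the target; a higher number here means a weaker inhibitor, a lower number a stronger inhibitor. Compound 1 `CC(O)(C(=O)Nc1cccc(S(=O)(=O)c2ccccc2)c1)C(F)(F)F` reaches only the limit of the assay, > 30000 nM. Compound 3 `CC(O)(C(=O)Nc1ccc(C(=O)c2ccccc2)cc1Br)C(F)(F)F` likewise stops at the limit, > 30000 nM. For the measured compounds named here, compound 2 `CC(O)(C(=O)Nc1ccc(S(=O)(=O)c2ccccc2C#N)cc1)C(F)(F)F` is the only member to return a number, 1100 nM in this assay. It therefore stands apart from the rest of the set, which sits at the limit of > 30000 nM in this assay, at which 2 of the 3 values shown sit. Going by the values given here, no two measured compounds differ in a single place, so no measured step is available, and nothing beyond compound 2 can be read as a trend.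

Compound 4 `CC(O)(C(=O)Nc1ccc(S(=O)(=O)c2ccccn2)cc1)C(F)(F)F` is to be measured next in this assay. It differs from compound 2 in one place (pyridin-2-yl in place of 2-cyanophenyl on a sulfonyl sulfur). The nitrile and the carbon-only ring leave; a ring with one hetero atom enters at the same sulfonyl sulfur. With no measured step of this kind in hand, the expectation is a modest loss of potency, somewhat beyond the usual scatter, given as the step of a 2.3-fold higher number from compound 2 to compound 4 (0.36 log units; beyond the scatter). Compound 4 is accordingly estimated at 2500 nM, with a range from 800 nM to 8000 nM.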

Compound 4, half-maximal inhibitory concentration: 600 nM
For compound 4 the middle estimate is 4.2-fold (0.62 log units) above the measured one; measured number outside the range, below it.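

For the compounds shown here, the first measured step at the sulfonyl sulfur in this assay is a 1.8-fold lower number from compound 2 to compound 4 (0.26 log units; within the scatter), with pyridin-2-yl in place of 2-cyanophenyl, and it lies within the scatter. Going by these compounds alone, the nitrile is therefore not required for a measured value at this place, and a six-membered aromatic ring with one hetero atom serves there as well as the carbon-only ring of 2-cyanophenyl, so compound 2 no longer stands alone as the only member of the series to return a number. Nothing measured in the set gives a reason why the two groups read alike, and the one line of support at hand, on how many values sit at the assay limit, does not bear on this step.

Still open, from the compounds shown here alone, is whether the sulfonyl sulfur keeps this level of activity with an amine or a carboxylic acid on the ring, or with a longer chain in place of the ring. Within the data shown here, compound 1 and compound 3 differ from compound 2 and compound 4 in more than one place, so no steps to them can be read.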